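Bromo for ethyl on the triazole-bound phenyl ring

The compounds below may be only part of what the source reports. "The series", "measured", "known", "first", "only" and "open" are said of these compounds alone.

Measured so far:
compound 1 `N#CC1=C(N)Oc2c(c3nc4ccccc4nc3c3ccccc23)C12C(=O)N(Cc1cnnn1-c1cccc(Br)c1)c1ccccc12`: > 50000 nM
compound 2 `CCc1ccccc1-n1nncc1CN1C(=O)C2(C(C#N)=C(N)Oc3c(N)cc4nc5ccccc5nc4c32)c2ccccc21`: 24600 nM

Of the compounds shown here, two have been tested in a functional assay on A549 cells (Homo sapiens) for antiproliferative activity, read by MTT assay, with a stated time of 48 h; a higher number here means a weaker inhibitor, a lower number a stronger inhibitor. Compound 1 reaches only the limit of the assay, at > 50000 nM, and so gives no number (the limit of > 50000 nM in this assay, at which 1 of the 2 values shown sits). Among the measured compounds shown here, compound 2 gives 24600 nM in this assay, the only number among the values shown. Compounds 1 and 2 differ in more than one place. Nothing beyond their two values can be said of the pair.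

Compound 3 `N#CC1=C(N)Oc2c(N)cc3nc4ccccc4nc3c2C12C(=O)N(Cc1cnnn1-c1ccccc1Br)c1ccccc12` has not yet been measured. It differs from compound 2 by a single change, (bromo in place of ethyl on an aromatic carbon). For the measured compounds named here, the group that leaves and the group that enters are both small and neither adds or removes a hydrogen-bond donor or acceptor, and no measured step shows what this swap does here.

Compound 3 is therefore expected to sit close to compound 2 in this assay, with a step of a 1.0-fold higher number from compound 2 to compound 3 (0.01 log units; within the scatter) that is expected to stay within the usual scatter. The estimated value of compound 3 is 25000 nM, expected to lie between 8000 nM and 80000 nM.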

Compound 3, half-maximal inhibitory concentration: 27400 nM
Estimate against measurement, compound 3: 1.1-fold (0.04 log units) below; the measured number falls inside the stated range.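

In this assay the change from 2-ethylphenyl to 2-bromophenyl gives the only step that can be read among these compounds, a 1.1-fold higher number from compound 2 to compound 3 (0.05 log units; within the scatter). At this place on the aromatic carbon, ortho to a large group, ethyl with its 2 heavy atoms and bromo with its 1 heavy atom are therefore not told apart by this read-out, and with the rest of the structure held the same, this exchange leaves antiproliferative activity where it was. Nothing measured here bears on why the two compounds read alike.

Whether this place accepts only groups of this kind stays open, since an amine, a carboxylic acid or a longer chain such as propyl on the same aromatic carbon has no value among the compounds shown, and neither has the unsubstituted phenyl ring. Among the compounds shown here, compound 1 remains a limit in this assay and differs from the other two compounds in more than one place, so no step to it can be read, and the effect of moving the bromo group on the phenyl ring cannot be separated from its other differences.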